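Replacing the amino group of compound 2

This account rests on a few compounds, and the source may have more. Where it says the series, first, only, none or still open, it means among the compounds named here.

In a functional assay on SK-MEL cells (Homo sapiens) for cytotoxicity, read by MTT assay, with a stated time of 6 days (a lower number here means that less compound is needed, a higher number that more compound is needed for the effect), compound 2 `Nc1ccc(-c2cc(=O)c3ccc(O)cc3o2)cc1` gives 6.59 ug/mL, the higher of the two numbers in hand, and compound 3 `COc1cc(-c2cc(=O)c3ccc(OC(C)=O)c(OC(C)=O)c3o2)cc(OC)c1O[Si](C)(C)C(C)(C)C` gives 0.14 ug/mL. Compound 1 `O=c1cc(-c2ccc([N+](=O)[O-])cc2)oc2cc(O)ccc12` reports only a limit, > 25 ug/mL. The next entry, compound 4 `CC(C)(C)[Si](C)(C)Oc1ccc(-c2cc(=O)c3ccc(O)cc3o2)cc1`, is reached by a group of 8 heavy atoms (6 carbon, 1 oxygen, 1 silicon; no ring) in place of one nitrogen atom, on an aromatic carbon: a group containing silicon in place of one nitrogen atom, on an aromatic carbon. Among the compounds with values here, the one measured step touching the amino group, an at least 3.7-fold lower number from compound 1 to compound 2 (0.57 log units; beyond the scatter), lies beyond the scatter, and its size rests on (the limit of > 25 ug/mL in this assay, at which 1 of the 3 values shown sits). Compound 3 also carries silicon and gives 0.14 ug/mL, which points to an expected lower number in this assay. The expected change is a 4.4-fold lower number from compound 2 to compound 4 (0.64 log units; beyond the scatter). For compound 4 the estimate is 1.5 ug/mL, with an expected range from 0.25 ug/mL to 8 ug/mL.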

Compound 4, concentration for half-maximal effect: 5.64 ug/mL
Beside the measured number, compound 4's estimate is 3.8-fold (0.58 log units) below it, and the stated range covers the measured number.
By their numbers in this assay, from the lowest: compound 3; then compounds 4 and 2 (each within the scatter of the next). At a limit, above all of these: compound 1.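

At this position, on an aromatic carbon para to a large group, this assay does not separate the amino group from the much larger silicon-containing group: a 1.2-fold lower number from compound 2 to compound 4 (0.07 log units; within the scatter). The position therefore accepts 8 heavy atoms and 0 hydrogen-bond donors in the entering group with no change beyond the scatter. The nitro group stands apart, with an at least 4.4-fold lower number from compound 1 to compound 4 (0.64 log units; beyond the scatter), and the size of that step rests on a limit of the assay: the limit of > 25 ug/mL in this assay, at which 1 of the 4 values shown sits.

From the compounds shown here alone, what a free hydroxyl, a methoxy or a carboxylic acid would give at this position stays open.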